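Swapping a Ring Pair on the Alkene Carbon

This account rests on a few compounds, and the source may have more. Where it says the series, first, only, none or still open, it means among the compounds named here.

Compound 2, with structure `CC/C(=C(/c1ccc(/C=C/C(=O)O)cc1)c1cnc2[nH]ncc2c1)c1ccccc1`, sits at the higher end of the two numbers recorded so far. In a functional assay on MCF7 cells (Homo sapiens) for cytotoxicity, read by CellTiter-Glo, with a stated time of 5 days (a higher number here means a weaker inhibitor, a lower number a stronger inhibitor), compound 2 gives 302 nM, while compound 1, with structure `C/C(=C(/c1ccc(/C=C/C(=O)O)cc1)c1ccc2[nH]ncc2c1)c1ccccc1`, gives 40 nM in this assay; the two compounds differ in more than one place, so only their two values can be set side by side, and compound 2 is the weaker inhibitor of the pair.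

Compound 3, with structure `CC/C(=C(/c1ccc(/C=C/C(=O)O)cc1)c1cc2cn[nH]c2cc1Cl)c1ccccc1`, has not yet been measured. It differs from compound 2 in one place: a group of 10 heavy atoms (7 carbon, 2 nitrogen, 1 chlorine; one five-membered aromatic ring with 2 hetero atoms, one six-membered aromatic ring of carbon only) in place of a group of 9 heavy atoms (6 carbon, 3 nitrogen; one five-membered aromatic ring with 2 hetero atoms, one six-membered aromatic ring with 1 hetero atom), on a double-bonded chain carbon bound to an aromatic carbon and a double-bonded chain carbon. The change brings back a six-membered aromatic ring of carbon only, as found in compound 1, and adds a chlorine to it, while the rest of the molecule stays as in compound 2.

Because compound 1 gives 40 nM with a carbon-only six-membered ring, a move toward a lower number is expected for compound 3, with a step from compound 2 to compound 3 of about a 4.3-fold lower number from compound 2 to compound 3 (0.63 log units; beyond the scatter), beyond the scatter. Compound 3 is estimated at 70 nM, with a likely range from 25 nM to 200 nM.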

Compound 3, half-maximal inhibitory concentration: 137 nM
Estimate against measurement, compound 3: 2.0-fold (0.29 log units) below; low and high end bracket the measured number.
By their numbers in this assay, from the lowest: compound 1; then compound 3; then compound 2.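

Going by these compounds alone, this is the first single-place comparison at the double-bonded chain carbon, and it shows that the group held there affects the cell result: in this assay, 6-chloro-1H-indazol-5-yl in place of the nitrogen-containing bicyclic group gives a 2.2-fold lower number from compound 2 to compound 3 (0.34 log units; beyond the scatter), a modest step but one that lies beyond the scatter. The change alters two features at once, since the six-membered aromatic ring becomes carbon only, with one hydrogen-bond acceptor fewer, and a chlorine also enters, so this single step cannot be divided between them. No measurement shown here explains the shift, so the result records an effect without giving its cause.

The data do not separate the loss of the ring nitrogen from the entry of the chlorine. Compound 1 differs from compound 3 in more than one place, and it cannot settle this. Keeping the rest of compound 3 fixed while using the plain 1H-indazol-5-yl group, or a fluorine or a methyl group in place of the chlorine, would separate the two contributions.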